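The source may report more compounds than this note shows. Statements on the series, on what has been measured and on what is new or still open speak of the compounds shown alone.

Measured in a functional assay on MCF7 cells (Homo sapiens) for antiproliferative activity, read by MTT assay, with a stated time of 48 h; a higher number here means a weaker inhibitor, a lower number a stronger inhibitor:
- Compound 1 `COC(=O)[C@H](C)NC(=O)c1ccc(Oc2nc3ccccc3nc2NC(C)(C)C)cc1` gives 38400 nM
- Compound 2 `CC[C@@H](C)[C@H](NC(=O)c1ccc(Oc2nc3ccccc3nc2NC(C)(C)C)cc1)C(=O)OC` gives 33400 nM
- Compound 3 `CCCCCCCCCCCCNc1nc2ccccc2nc1Oc1ccc(C(=O)N[C@H](C(=O)O)[C@H](C)CC)cc1` gives 30400 nM

Compound 3 stands within the usual scatter of both compound 1 and compound 2, so these numbers do not separate the three compounds. Compound 4 `CC[C@@H](C)[C@H](NC(=O)c1ccc(Oc2nc3ccccc3nc2NC(C)(C)C)cc1)C(=O)O` differs from compound 3 in one place, with tert-butyl in place of dodecyl on a nitrogen on an aromatic ring.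

Within the data shown here, no measured step isolates this swap, and no pair of measured compounds shows tert-butyl against dodecyl alone. Among the measured compounds shown here, the only single-place step, a 1.1-fold lower number from compound 1 to compound 2 (0.06 log units; within the scatter), concerns a different change and stays within the scatter. For the measured compounds named here, compound 2 carries tert-butyl and gives 33400 nM, a value within the scatter of the one for compound 3, which carries dodecyl. That is indirect evidence, but it gives no reason to expect a real shift, so no change beyond the scatter is expected in this assay. The expected size of the change is a 1.3-fold higher number from compound 3 to compound 4 (0.12 log units; within the scatter), and the thin evidence calls for a wide range. For compound 4 the estimated value is 40000 nM, with an estimated range from 18000 nM to 90000 nM.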

Compound 4, half-maximal inhibitory concentration: 11400 nM
Beside the measured number, compound 4's estimate is 3.5-fold (0.55 log units) above it; the measured number lies below the stated range.
By their numbers in this assay, from the lowest: compound 4; then compounds 3, 2 and 1 (each within the scatter of the next).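

In this assay, among these compounds, the step of a 2.7-fold lower number from compound 3 to compound 4 (0.43 log units; beyond the scatter) shows that the group on a nitrogen on an aromatic ring does matter: with tert-butyl in place of dodecyl, the number moves beyond the scatter, something no earlier pair could show. The other end of the molecule matters as well: the step of a 2.9-fold lower number from compound 2 to compound 4 (0.47 log units; beyond the scatter) comes with hydrogen in place of methyl on an oxygen next to a carbonyl group, and the step of a 3.4-fold lower number from compound 1 to compound 4 (0.53 log units; beyond the scatter) comes with 1-carboxy-2-methylbutyl in place of 1-(methoxycarbonyl)ethyl on an amide-type nitrogen. All three steps are modest, yet they set compound 4 apart as the lowest number of the four, whereas compounds 1, 2 and 3 could not be told apart.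

As far as these compounds go, it remains open whether a mid-length chain such as hexyl, or a ring such as cyclohexyl, on that nitrogen would land nearer compound 3 or compound 4, and whether a primary amide in place of the carboxylic acid would keep the lower number. Nothing in the data at hand offers a reason for any of these steps.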